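The source may hold more compounds than are shown below. What is called first, only, known or untested is meant among the compounds shown, and "the series" means these compounds.

The account begins with three measured compounds built on one shared core. Compound 1 `CC(C)=CCC1Cc2c(O)cc(=O)n(CCCO)c2CC1(C)C` gives 25.6% in a functional assay on PANC-1 cells (Homo sapiens) for inhibition, read by MTT assay, with a stated time of 24 h, tested at 10 uM; on this read-out higher numbers stand for more inhibition at the one concentration tested (going by the name of the read-out) and lower numbers for less inhibition. Compound 2 `CC(C)=CCC/C(C)=C/CC1Cc2c(O)cc(=O)n(CCCO)c2CC1(C)C`, which carries 3-methylbut-2-en-1-yl in place of hydrogen on a saturated chain carbon bound to a double-bonded chain carbon, gives in this assay 28.7%; the step of a number 3.1 percentage points higher from compound 1 to compound 2 (within the scatter) lies within the scatter, so these two cannot be ranked against each other. Compound 3 `CC(C)=CCC1Cc2c(OC(=O)Nc3ccc(F)cc3F)cc(=O)n(CCCO)c2CC1(C)C` gives 69.7% in this assay, and a number 44.1 percentage points higher from compound 1 to compound 3 (beyond the scatter) is the one large movement among the three. Compound 2 thus stands together with compound 1 on the numbers shown and well below compound 3.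

The unmeasured compound 4 `COc1ccccc1NC(=O)Oc1cc(=O)n(CCCO)c2c1CC(C/C=C(\C)CCC=C(C)C)C(C)(C)C2` differs from compound 2 in one place: (2-methoxyphenyl)carbamoyl in place of hydrogen on an oxygen on an aromatic ring. The measured step that bears on this is a number 44.1 percentage points higher from compound 1 to compound 3 (beyond the scatter), in which a different carbamoyl entered on an oxygen on an aromatic ring. The change on the way to compound 4 is not identical, but it is of the same kind, so a rise of roughly that size is expected rather than a step within the scatter. Compound 4 is therefore estimated to give about 68% in this assay, with a range from 50% to 85%. That expectation amounts to a step of a number 39.3 percentage points higher from compound 2 to compound 4 (beyond the scatter). Whether the measurement bears this out is what the continuation will tell.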

Compound 4, a percentage reported as inhibition, at one concentration (the size of the read-out at that concentration, not a potency): 53%
Compound 4: middle estimate off by 15 percentage points, on the high side, within the range that was stated.
By their numbers in this assay, from the lowest: compounds 1 and 2 (each within the scatter of the next); then compound 4; then compound 3.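

In this assay the carbamoyl change at this oxygen gives a number 24.3 percentage points higher from compound 2 to compound 4 (beyond the scatter), so the rise seen earlier as a number 44.1 percentage points higher from compound 1 to compound 3 (beyond the scatter) is not confined to compound 1 and also appears with the added 3-methylbut-2-en-1-yl present and with (2-methoxyphenyl)carbamoyl as the entering group. Both steps lie beyond the scatter, but compound 3 and compound 4 differ in two places, the chain and the carbamoyl group, so the difference in size between the two rises cannot be assigned to either one. Nothing among the data explains why either carbamoyl raises the number.

The compounds shown leave open how (2-methoxyphenyl)carbamoyl would behave on the shorter chain of compound 1, the one comparison that would separate the chain from the carbamoyl group. They also leave open whether the rise needs an aromatic ring on the carbamoyl at all, as an ethylcarbamoyl or a plain acetyl on the same oxygen would show.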